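Rearranging a Bicyclic Group on the Lactam Nitrogen

This account rests on a few compounds, and the source may have more. Where it says the series, first, only, none or still open, it means among the compounds named here.

For the measured compounds named here, compound 1 `Cc1c(S(=O)(=O)N[C@H]2CCN(Cc3cc4[nH]cccc-4n3)C2=O)sc2ccc(Cl)cc12` gives 40% in an assay on isolated protein for inhibition of coagulation factor X (Oryctolagus cuniculus), tested at 1 uM (on this read-out higher numbers stand for more inhibition at the one concentration tested (going by the name of the read-out) and lower numbers for less inhibition), the higher of the two numbers known so far; compound 2 `O=C1[C@@H](NS(=O)(=O)c2ccc(-c3ccncc3)s2)CCN1Cc1cc2[nH]cccc-2n1` gives 35% in this assay, a number within the scatter of compound 1, so the two cannot be told apart. Compound 3 `Cc1c(S(=O)(=O)N[C@H]2CCN(Cc3cc4cc[nH]cc-4n3)C2=O)sc2ccc(Cl)cc12` has the same atoms as compound 1, joined differently: a group of 9 heavy atoms (7 carbon, 2 nitrogen; one five-membered aromatic ring with 1 hetero atom, one six-membered aromatic ring with 1 hetero atom) in place of a group of 9 heavy atoms (7 carbon, 2 nitrogen; one five-membered aromatic ring with 1 hetero atom, one six-membered aromatic ring with 1 hetero atom), on a saturated chain carbon bound to an amide-type nitrogen in a ring. Going by the values given here, no measured pair shows what such a rearrangement does. In this assay the step is therefore expected to stay small, a number 5 percentage points lower from compound 1 to compound 3 (within the scatter), with no clear direction. Compound 3 is estimated at 35%, ranging from 10% to 60%.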

Compound 3, a percentage reported as inhibition, at one concentration (the size of the read-out at that concentration, not a potency): 52%
Compound 3: middle estimate off by 17 percentage points, on the low side; the range from low to high includes it.
By their numbers in this assay, from the lowest: compounds 2 and 1 (each within the scatter of the next); then compound 3.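

Rearranging the bicyclic group on the saturated chain carbon bound to an amide-type nitrogen in a ring does register in this assay, with a number 12 percentage points higher from compound 1 to compound 3 (beyond the scatter) as a modest step. The leaving and entering groups have the same atoms, rings, hydrogen-bond donor and hydrogen-bond acceptor, so the way the atoms are joined is enough to shift this number. Nothing measured here explains the shift. As far as these compounds go, whether the same rearrangement carries over to the sulfonyl group of compound 2 remains open. So does the outcome of adding an amine or a carboxylic acid to the rearranged bicyclic group.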